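Cyclohexyl in place of pyridinyl on the shared core

This account rests on a few compounds, and the source may have more. Where it says the series, first, only, none or still open, it means among the compounds named here.

Compound 1 `O[C@@H](c1ccccc1)[C@H]1CO[C@H](c2ccccc2)[C@@H](C/C=C/c2ccccn2)C1` was tested in a functional assay on HeLa cells (Homo sapiens) for cytotoxicity, read by WST assay, with a stated time of 48 h (on this read-out higher numbers stand for weaker inhibition and lower numbers for stronger inhibition), and gives 33800 nM. Among the compounds with values here, its number stands second highest of the three measured so far; compound 2 `COc1ccc([C@H](O)[C@H]2CO[C@@H](c3ccc(OC)c(OC)c3)[C@H](C/C=C/c3ccc(OC)c(OC)c3)C2)cc1` gives 32200 nM and compound 3 `COc1ccc([C@H](O)[C@H]2CO[C@H](c3ccc(OC)c(OC)c3)[C@@H](C/C=C/c3ccc(OC)c(OC)c3)C2)cc1` gives 46000 nM, and both gaps to compound 1 lie within the scatter. Within the data shown here, the only step between compounds differing in one place is a 1.4-fold higher number from compound 2 to compound 3 (0.15 log units; within the scatter), which rests on (the fact that compounds 2 and 3 differ only in the configuration as drawn); it concerns configuration alone and so says nothing about the change to compound 4 `O[C@@H](c1ccccc1)[C@H]1CO[C@H](c2ccccc2)[C@@H](C/C=C/C2CCCCC2)C1`. That change is cyclohexyl in place of pyridin-2-yl on a double-bonded chain carbon bound to a double-bonded chain carbon. Among the measured compounds shown here, no measured step bears on it, and the step of a 1.0-fold higher number from compound 1 to compound 4 (0.00 log units; within the scatter) is expected to stay within the scatter. Compound 4 is estimated at 34000 nM, expected to fall between 15000 nM and 75000 nM.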

Compound 4, half-maximal inhibitory concentration: 6440 nM
The estimate for compound 4 lay 5.3-fold (0.72 log units) above the measured number; measured number below the stated range.
By their numbers in this assay, from the lowest: compound 4; then compounds 2, 1 and 3 (each within the scatter of the next).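

In this assay, within the data shown here, cyclohexyl in place of pyridin-2-yl gives a 5.2-fold lower number from compound 1 to compound 4 (0.72 log units; beyond the scatter) on the shared core, the first step at this place on the chain and the first to lie beyond the scatter. The swap replaces an aromatic ring holding one nitrogen, a hydrogen-bond acceptor, with a non-aromatic ring of carbon only, with the same count of heavy atoms, so these differences arrive together. Nothing shown explains the shift.

Open, as far as these compounds go, is whether losing the ring nitrogen or losing the aromatic ring matters more. An unsubstituted phenyl or a piperidinyl group at this place would separate the two.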